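Larger ring-bearing group on the aromatic nitrogen

The source may report more compounds than this note shows. Statements on the series, on what has been measured and on what is new or still open speak of the compounds shown alone.

Compound 2 `CN1C(=S)[C@@H](NC(=O)c2nc(Cc3ccccc3)n(CCCO)n2)COc2ccccc21` gives 209 nM in a functional assay on HT-29 cells (Homo sapiens) for inhibition, read by luminescence and CellTiter-Glo, with a stated time of 24 h (on this read-out lower numbers stand for an effect already at smaller amounts and higher numbers for an effect only at larger amounts of compound), the lowest of three numbers. Its neighbour compound 1 `CC(C)n1nc(C(=O)N[C@H]2COc3ccccc3N(C)C2=S)nc1Cc1ccccc1` gives 360 nM, and the step of a 1.7-fold lower number from compound 1 to compound 2 (0.24 log units; within the scatter) stays within the scatter. Compound 3 `CN1C(=S)[C@@H](NC(=O)c2nc(Cc3ccccc3)n(C3CCOCC3)n2)COc2ccccc21` gives 2260 nM, and the step of an 11-fold higher number from compound 2 to compound 3 (1.03 log units; beyond the scatter) is large. Compound 4 `CN1C(=S)[C@@H](NC(=O)c2nc(Cc3ccccc3)n(C3CCN(C(=O)OC(C)(C)C)C3)n2)COc2ccccc21` carries a different change on the same aromatic nitrogen: a group of 12 heavy atoms (9 carbon, 1 nitrogen, 2 oxygen; one five-membered non-aromatic ring with 1 hetero atom) in place of a group of 4 heavy atoms (3 carbon, 1 oxygen; no ring), on an aromatic nitrogen. The two steps that bear on it both put a ring on this nitrogen: a 6.3-fold higher number from compound 1 to compound 3 (0.80 log units; beyond the scatter) was modest, and an 11-fold higher number from compound 2 to compound 3 (1.03 log units; beyond the scatter) was large. Since both ring-bearing groups gave higher numbers, a higher number is expected for compound 4 as well, because of an 11-fold higher number from compound 2 to compound 3 (1.03 log units; beyond the scatter) in particular. Compound 4 is therefore estimated at 2000 nM, with a range from 500 nM to 8000 nM, meaning an expected step of a 9.6-fold higher number from compound 2 to compound 4 (0.98 log units; beyond the scatter).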

Compound 4, half-maximal effective concentration: > 10000 nM
Compound 4: only a limit was reported (the forecaster's own chance of this, stated with the estimate: 5%); at least 5.0-fold (0.69 log units) between middle value and limit.
By their numbers in this assay, from the lowest: compounds 2 and 1 (each within the scatter of the next); then compound 3. At a limit, above all of these: compound 4.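

For compound 4 this assay gives only a limit, not a number: the limit of > 10000 nM in this assay, at which 1 of the 4 values shown sits. On this aromatic nitrogen, the group of 12 heavy atoms stands far from the open chains, with an at least 47-fold higher number from compound 2 to compound 4 (1.67 log units; beyond the scatter) and an at least 27-fold higher number from compound 1 to compound 4 (1.44 log units; beyond the scatter), and it also goes beyond the oxan-4-yl ring, with an at least 4.4-fold higher number from compound 3 to compound 4 (0.64 log units; beyond the scatter). So the two ring-bearing groups shown are not equal here, and the larger one gives the higher reading.

The compounds shown do not separate the size of this group from its ring or its carbonyl part. Also open, going by these compounds, is how the same five-membered ring with a free amine, or a chain ending in a carboxylic acid, would read at this nitrogen.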